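From furan-2-yl to propyl on an aromatic nitrogen

The compounds below may be only part of what the source reports. "The series", "measured", "known", "first", "only" and "open" are said of these compounds alone.

In a functional assay on cells (Platelet, Homo sapiens) for inhibition (on this read-out higher numbers stand for weaker inhibition and lower numbers for stronger inhibition), compound 3 (`CCOC(=O)c1ccc(-c2nn(-c3ccco3)c3ccccc23)cc1`) gives > 10000 nM, which is a limit and not a number. Compound 1 (`CCOC(=O)c1ccc(-c2nn(Cc3cccc(F)c3)c3ccccc23)cc1`) also stands at a limit, > 10000 nM. Compound 2 (`CCOC(=O)c1ccc(-c2nn(Cc3ccc(F)cc3)c3ccccc23)cc1`) does too, at > 10000 nM. Compound 4 (`CCCn1nc(-c2ccc(C(=O)OCC)cc2)c2ccccc21`) has propyl in place of furan-2-yl on an aromatic nitrogen. The closest evidence comes from the same nitrogen, in a step that the two limits leave unreadable from compound 1 to compound 3 and a step that the two limits leave unreadable from compound 2 to compound 3, and neither has a readable size. Within the data shown here, the series so far offers only (the limit of > 10000 nM in this assay, at which 3 of the 3 values shown sit). No shift in either direction can therefore be predicted, and the expected change is a number no higher from compound 3 to compound 4 (the limit leaves the size open). Compound 4 is estimated at 10000 nM, with an expected range of 4000 nM to 20000 nM.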

Compound 4, half-maximal inhibitory concentration: > 10000 nM
Compound 4 gave a limit, no number; the forecaster's own chance of this, stated with the estimate: 80%; the middle value sits exactly at the limit.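

Among these compounds, compound 4 also stands at a limit, > 10000 nM, so no step from compound 1, compound 2 or compound 3 to compound 4 can be read. The compounds shown leave open whether any group on this aromatic nitrogen changes inhibition in this assay: the limit of > 10000 nM in this assay, at which 4 of the 4 values shown sit.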